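The source may report more compounds than this note shows. Statements on the series, on what has been measured and on what is new or still open speak of the compounds shown alone.

Compound 1 `CNc1nc(SCc2nc3ccccc3[nH]2)nc(-c2ccccc2)c1C#N`: 13.2 nM
Compound 2 `N#Cc1c(Nc2ccccn2)nc(SCc2nc3ccccc3[nH]2)nc1-c1ccccc1`: 7 nM

In a functional assay on K562 cells (Homo sapiens) for cytotoxicity, read by MTT assay, with a stated time of 3 days (on this read-out lower numbers stand for stronger inhibition and higher numbers for weaker inhibition), compound 2 gives 7 nM and stands within the scatter of compound 1 at 13.2 nM. Compound 3 `N#Cc1c(NC(N)=S)nc(SCc2nc3ccccc3[nH]2)nc1-c1ccccc1` has not been measured and differs from compound 2 as follows: a group of 3 heavy atoms (1 carbon, 1 nitrogen, 1 sulfur; no ring) in place of a group of 6 heavy atoms (5 carbon, 1 nitrogen; one six-membered aromatic ring with 1 hetero atom), on a nitrogen on an aromatic ring. Within the data shown here, only one measured step bears on this place, a 1.9-fold lower number from compound 1 to compound 2 (0.28 log units; within the scatter), and it stays within the scatter. The data therefore give no reason to expect a large change in this assay, though the group entering is new. The expected step is a 1.4-fold higher number from compound 2 to compound 3 (0.15 log units; within the scatter), which is not expected to exceed the scatter. For compound 3 the estimate is 10 nM, with an expected range of 3 nM to 35 nM.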

Compound 3, half-maximal inhibitory concentration: 11.9 nM
Estimate against measurement, compound 3: 1.2-fold (0.08 log units) below; the measured number falls inside the stated range.
By their numbers in this assay, from the lowest: compounds 2, 3 and 1 (each within the scatter of the next).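

In this assay the new group on the nitrogen, which has no ring and brings a double bond outside aromatic rings, shows a 1.7-fold higher number from compound 2 to compound 3 (0.23 log units; within the scatter) when it replaces pyridin-2-yl and a 1.1-fold lower number from compound 1 to compound 3 (0.05 log units; within the scatter) when it replaces methyl. Among these compounds, this position has therefore now carried three unlike groups, one of them without a ring or a double bond, and no step among them leaves the scatter. Nothing shown explains this result. Going by these compounds, whether an amine, a carboxylic acid or a longer alkyl chain on this nitrogen would stay within the scatter remains open. So does whether these three compounds would stay this close on cells other than K562.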